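Removing an Allyl Group on Two Related Cores

This account rests on a few compounds, and the source may have more. Where it says the series, first, only, none or still open, it means among the compounds named here.

Of the compounds shown here, three have so far been tested in a functional assay on MCF7 cells (Homo sapiens) for cytotoxicity, read by sulforhodamine B assay, with a stated time of 48 h; a higher number here means a weaker inhibitor, a lower number a stronger inhibitor. Compound 1 `C=CCOc1c(Cl)cccc1C(=O)c1cccnc1` gives > 100000 nM, which is a limit of the assay and not a number (the limit of > 100000 nM in this assay, at which 1 of the 3 values shown sits). Compound 2 `O=C(c1cccnc1)c1cccc(Cl)c1O` gives 26700 nM in this assay. Compound 3 `C=CCOc1ccc(C)cc1C(=O)c1cccnc1` gives 84000 nM in this assay. Compound 3 and compound 1 rest on related but distinct cores; the difference between the two cores is not broken down here.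

Compound 2 arises from compound 1 by a single change (hydrogen in place of allyl on an oxygen on an aromatic ring). In this assay the result was an at least 3.7-fold lower number from compound 1 to compound 2 (0.57 log units; beyond the scatter). Since the starting value is only a limit, the true size of that step could be larger than the bound shows.

Compound 4 `Cc1ccc(O)c(C(=O)c2cccnc2)c1` has not yet been measured. It differs from compound 3 by the same change (hydrogen in place of allyl on an oxygen on an aromatic ring), made at the same kind of place, an oxygen on an aromatic ring whose other neighbours are aromatic carbon. Among the compounds shown, this change occurs two times in all.

The step from compound 3 to compound 4 in this assay is expected to be a 3.4-fold lower number from compound 3 to compound 4 (0.53 log units; beyond the scatter), an expectation that rests on the earlier change having given an at least 3.7-fold lower number from compound 1 to compound 2 (0.57 log units; beyond the scatter). Compound 4 is accordingly expected to give about 25000 nM in this assay. A plausible range for compound 4 is estimated to run from 8000 nM to 80000 nM.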

Compound 4, half-maximal inhibitory concentration: 8040 nM
For compound 4 the middle estimate is 3.1-fold (0.49 log units) above the measured one; the measured number falls inside the stated range.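

On the core of compound 3, putting hydrogen in place of allyl on the oxygen gave a 10-fold lower number from compound 3 to compound 4 (1.02 log units; beyond the scatter) in this assay, which is the same direction as the change gave on the core of compound 1. Compound 1 gives > 100000 nM, which is a limit of the assay and not a number. The direction of the change therefore carried over between these two cores, but this does not show that its size carried over, and two cores are too few to make a rule for the series, as a comparison of the two steps makes clear: the same change on two cores in this assay, an at least 3.7-fold lower number (0.57 log units; beyond the scatter) from compound 1 to compound 2 and a 10-fold lower number (1.02 log units; beyond the scatter) from compound 3 to compound 4; the limit leaves it open whether they differ.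

The compounds shown leave open whether the lower number depends on the hydroxy group itself or simply on the allyl group being gone, since only allyl and hydrogen appear on that oxygen; an ethyl chain on the same oxygen, or an amine in place of the hydroxy, would help to separate the two readings. They also leave open whether the same direction would appear on a third core, such as one carrying a carboxylic acid in place of the chloro or methyl group.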